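Methoxy in Place of Methyl on the Thiourea Aryl Ring

A few compounds are considered here, and "the series" means these few. Any claim that something is new, unique, unknown or untested is made for them only; others in the source may bear on it.

Compound 1: `NC(=O)c1c(NC(=O)c2ccccc2Cl)sc2c1CCN(Cc1cc(Cl)cc(Cl)c1)C2` — 19600 nM
Compound 2: `Cc1ccccc1NC(=S)N1CCc2c(sc(NC(=O)c3ccccc3Cl)c2C(N)=O)C1` — > 50000 nM

In a functional assay on HeLa cells (Homo sapiens) for antiproliferative activity, with a stated time of 24 h (a lower number here means a stronger inhibitor, a higher number a weaker inhibitor), compound 1 gives 19600 nM. Compound 2 reaches only a limit of the assay, > 50000 nM. That limit is the limit of > 50000 nM in this assay, at which 1 of the 2 values shown sits, so compound 2 stands at the weak edge of what the assay reports. Among the measured compounds shown here, the one measured step, an at least 2.5-fold higher number from compound 1 to compound 2 (0.40 log units; beyond the scatter), exchanges the group on the ring amine nitrogen and is the only comparison available.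

Compound 3 is `COc1ccccc1NC(=S)N1CCc2c(sc(NC(=O)c3ccccc3Cl)c2C(N)=O)C1`. The change from compound 2 to compound 3 is methoxy in place of methyl on an aromatic carbon. For the measured compounds named here, no measured step touches this aryl ring, so the measured steps give no direct guide to the size or direction of the step; the change is small and compound 2 already sits at a limit. Compound 3 is therefore expected to stay near that limit, with an estimated value of 50000 nM, in a range from 20000 nM to 150000 nM. The expected step is a number no higher from compound 2 to compound 3 (the limit leaves the size open), which is not expected to reach beyond the scatter.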

Compound 3, half-maximal inhibitory concentration: > 50000 nM
Compound 3: no number, only a limit (the forecaster's own chance of this, stated with the estimate: 70%); the middle value sits exactly at the limit.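

In this assay compound 3 gives > 50000 nM, which is a limit and not a number. Methoxy in place of methyl on this aromatic carbon, ortho to a large group, leaves the thiourea compounds at the weak edge of the assay, and the step between compound 2 and compound 3 cannot be read because both compounds stand at the same limit: the limit of > 50000 nM in this assay, at which 2 of the 3 values shown sit. The comparison that remains readable is an at least 2.5-fold higher number from compound 1 to compound 3 (0.40 log units; beyond the scatter), so the group carrying 2-methoxyphenyl on the ring amine nitrogen, like the one carrying 2-methylphenyl, reads as weaker than the group it replaces.

As far as these compounds go, how far methyl and methoxy differ at this position stays open, since neither compound has a number in this assay. Also open, from the compounds shown here alone, is whether an amine or a carboxylic acid on this aryl ring, or a urea oxygen in place of the thiourea sulfur, would bring a compound back within the readable range.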